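The source may report more compounds than this note shows. Statements on the series, on what has been measured and on what is new or still open speak of the compounds shown alone.

Of the compounds shown here, two with a shared core have been measured so far. Compound 1 `CC1=C(C(=O)OC(C)(C)C)C(c2ccco2)NC(=S)N1` gives 9% in an assay on membranes from HEK293 cells for displacement of a labelled ligand from adenosine receptor A2b (Homo sapiens), read by scintillation counting, with a stated time of 30 min, tested at 1 uM; a higher number here means more inhibition at the concentration tested (going by the name of the read-out), a lower number less inhibition. Within the data shown here, compound 2 `CC1=C(C(=O)OCc2ccccc2)C(c2ccco2)NC(=S)N1` gives 41% in this assay, and the one step between them, a number 32 percentage points higher from compound 1 to compound 2 (beyond the scatter), is the sole measured step. Among the measured compounds shown here, compound 2 thus stands highest of the two numbers, with compound 1 as its only neighbour.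

The next compound, compound 3 `CC1=C(C(=O)OCc2ccccc2)C(c2ccsc2)NC(=S)N1`, differs from compound 2 in one place: thiophen-3-yl in place of furan-2-yl on a saturated ring carbon. For the measured compounds named here, no measured step touches this position; the single step from compound 1 to compound 2 changes the ester group and says nothing about an exchange of the aromatic ring on the saturated ring carbon. Compound 3 is therefore expected to stay close to compound 2, with an estimated step of a number 1 percentage points lower from compound 2 to compound 3 (within the scatter) in this assay, which is no change beyond the scatter. For compound 3 the estimate in this assay is 40%, with a range from 20% to 60%.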

Compound 3, a percentage reported as inhibition, at one concentration (the size of the read-out at that concentration, not a potency): 10%
The estimate for compound 3 lay 30 percentage points above the measured number, outside the stated range (below it).
By their numbers in this assay, from the lowest: compounds 1 and 3 (each within the scatter of the next); then compound 2.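

In this assay the exchange of furan-2-yl for thiophen-3-yl on the saturated ring carbon gives a number 31 percentage points lower from compound 2 to compound 3 (beyond the scatter) and so shows that this position, untouched by the earlier ester step, is sensitive to which five-membered aromatic ring it carries. The two rings match in heavy atoms, hetero atom count, hydrogen-bond donors and acceptors and net charge, so these counts do not separate them; they differ in oxygen against sulfur and in the ring atom of attachment, and this single step changes both together. No evidence at hand bears on why the number falls.

Which of those two differences matters remains open, and thiophen-2-yl on the same carbon would separate them. Whether a phenyl ring there would keep or lose the number of compound 2 is also unknown.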